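The source may hold more compounds than are shown below. What is called first, only, known or untested is meant among the compounds shown, and "the series" means these compounds.

Measured so far in a functional assay on RKO cells (Homo sapiens) for inhibition, read by MTT assay, with a stated time of 48 h; a higher number here means a weaker inhibitor, a lower number a stronger inhibitor:
compound 1 (`COc1ccc(N(C)c2nc(C)nc3ccccc23)cc1OCCCCCC[Se]C#N`): 1540 nM
compound 2 (`COc1ccc(N(C)c2nc(C)nc3ccccc23)cc1OCCCC[Se]C#N`): 1360 nM

Compound 2 stands level with compound 1 on these numbers, as the two values lie within the scatter of each other. Compound 3 (`COc1ccc(N(C)c2nc(C)nc3ccccc23)cc1OCCCCC[Se]C#N`) differs from compound 2 by a group of 4 heavy atoms (2 carbon, 1 nitrogen, 1 selenium; no ring) in place of a group of 3 heavy atoms (1 carbon, 1 nitrogen, 1 selenium; no ring), on a saturated chain carbon, four bonds along the chain from an oxygen on an aromatic ring and in no other way. Among the compounds with values here, one measured step bears on this change, at the same place on the chain. That step, a 1.1-fold lower number from compound 1 to compound 2 (0.05 log units; within the scatter), put a group of 3 heavy atoms in place of a group of 5 heavy atoms and stayed within the scatter. The group entering compound 3 has a size inside that span, so no step beyond the scatter is expected in this assay, and no direction can be favoured. The expected step is a 1.1-fold higher number from compound 2 to compound 3 (0.03 log units; within the scatter) and this is only an estimate. For compound 3 the estimated value is 1450 nM with an expected range from 800 nM to 2600 nM in this estimate.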

Compound 3, half-maximal inhibitory concentration: 3560 nM
Estimate against measurement, compound 3: 2.5-fold (0.39 log units) below, and the stated range ends below it.
By their numbers in this assay, from the lowest: compounds 2 and 1 (each within the scatter of the next); then compound 3.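

In this assay this position proved sensitive to a change of a single chain carbon, which the earlier pair had not suggested: the group of 4 heavy atoms gave a 2.6-fold higher number from compound 2 to compound 3 (0.42 log units; beyond the scatter) and, approached from the other side, a 2.3-fold higher number from compound 1 to compound 3 (0.36 log units; beyond the scatter). The response to chain size at this place is therefore not steady, since compound 3, whose group lies in size between those of compound 2 and compound 1, is the weakest of the three, while those two remain level with each other. No available evidence bears on this rise.

The compounds shown leave open whether a shorter chain or a longer chain would continue this uneven pattern. They also leave open whether sulfur in place of selenium would change the number at any of these chain lengths.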